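Dimethoxyphenyl Variant of an Arylpiperazine Aortic Antagonist

The source may report more compounds than this note shows. Statements on the series, on what has been measured and on what is new or still open speak of the compounds shown alone.

Among the measured compounds shown here, compound 1 `CCOc1ccccc1N1CCN(CCCNc2ncccc2C(=O)N(C)C)CC1` gives 7.94 nM in a functional assay on aorta for antagonist activity at Alpha-1D adrenergic receptor (Rattus norvegicus) (on this read-out lower numbers stand for tighter binding and higher numbers for weaker binding), the lowest of the three numbers measured so far. Compound 2 `CN(C)C(=O)c1cccnc1NCCCN1CCN(c2ccccc2OCC2CC2)CC1` gives 10 nM in this assay, and the step of a 1.3-fold higher number from compound 1 to compound 2 (0.10 log units; within the scatter) stays within the scatter. Compound 3 `CN(C)C(=O)c1cccnc1NCCCN1CCN(c2ccccc2Cc2ccccc2)CC1` gives 79.4 nM in this assay, reached through the step of a 10-fold higher number from compound 1 to compound 3 (1.00 log units; beyond the scatter); the step of a 7.9-fold higher number from compound 2 to compound 3 (0.90 log units; beyond the scatter) points the same way. Compound 4 `COc1ccc(N2CCN(CCCNc3ncccc3C(=O)N(C)C)CC2)c(OC)c1` awaits measurement; it differs from compound 1 in that (2,4-dimethoxyphenyl in place of 2-ethoxyphenyl on an amine nitrogen in a ring). Both measured steps alter the group on the aromatic ring: exchanging one alkoxy chain for another changed little, while replacing it with benzyl weakened binding modestly. Compound 4 keeps an alkoxy group there and adds a second methoxy. Compound 4 is therefore expected to show a small step of a 1.9-fold higher number from compound 1 to compound 4 (0.28 log units; within the scatter) in this assay, with an estimated 15 nM between 5 nM and 50 nM.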

Compound 4, dissociation constant: 1000 nM
Estimate against measurement, compound 4: 67-fold (1.82 log units) below; the measured number lies above the stated range.
By their numbers in this assay, from the lowest: compounds 1 and 2 (each within the scatter of the next); then compound 3; then compound 4.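

In this assay, putting 2,4-dimethoxyphenyl in place of 2-ethoxyphenyl on an amine nitrogen in a ring gives a 130-fold higher number from compound 1 to compound 4 (2.10 log units; beyond the scatter) and is the largest step shown. Keeping alkoxy groups on this aromatic ring therefore does not by itself hold the number near that of compound 1, and compound 4 lies further from it than the benzyl compound 3. Nothing measured here accounts for the step. The step combines two changes, so the added methoxy and the exchange of ethoxy for methoxy remain unseparated. A plain 2-methoxyphenyl group would separate them.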